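Hydroxy to methoxy: an expected step in growth inhibition

The source may report more compounds than this note shows. Statements on the series, on what has been measured and on what is new or still open speak of the compounds shown alone.

In a functional assay on SF-268 cells (Homo sapiens) for antiproliferative activity, read by sulforhodamine B assay, with a stated time of 48 h (on this read-out lower numbers stand for stronger inhibition of growth and higher numbers for weaker inhibition of growth), compound 1 `O=C(NCCCNc1cc(-c2cn(-c3ccccc3)nc2-c2cccc(O)c2)ccn1)Nc1ccc(F)cc1` gives 11200 nM. Among the measured compounds shown here, compound 2 `O=C(NCCCNc1cc(-c2cn(-c3ccccc3)nc2-c2cccc(O)c2)ccn1)Nc1cccc(C(F)(F)F)c1` gives 9690 nM, so the only two measured compounds stand level within the scatter, and compound 1 has no clear rank between them. Compound 3 `COc1cccc(-c2nn(-c3ccccc3)cc2-c2ccnc(NCCCNC(=O)Nc3ccc(F)cc3)c2)c1` departs from compound 1 in one place: methyl in place of hydrogen on an oxygen on an aromatic ring. This turns 3-hydroxyphenyl into 3-methoxyphenyl. For the measured compounds named here, the single measured step, a 1.2-fold lower number from compound 1 to compound 2 (0.06 log units; within the scatter), lies elsewhere, on an amide-type nitrogen, so it gives only a loose guide to size and none to direction for this change. Going by the values given here, no measured compound carries the methoxy group. In this assay, no change beyond the scatter is therefore expected. The expected step is a 1.2-fold higher number from compound 1 to compound 3 (0.06 log units; within the scatter). For compound 3 the estimated value is 13000 nM, with an expected range from 5500 nM to 32000 nM.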

Compound 3, concentration for total growth inhibition: 30000 nM
Estimate against measurement, compound 3: 2.3-fold (0.36 log units) below, and the stated range covers the measured number.
By their numbers in this assay, from the lowest: compounds 2 and 1 (each within the scatter of the next); then compound 3.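

In this assay, methyl in place of hydrogen on the aromatic oxygen gives a 2.7-fold higher number from compound 1 to compound 3 (0.43 log units; beyond the scatter) and so moves the number toward weaker inhibition of growth. The earlier step, a 1.2-fold lower number from compound 1 to compound 2 (0.06 log units; within the scatter) on an amide-type nitrogen, showed no change beyond the scatter, which makes this oxygen the first place among the compounds shown where a single change registers, though the step is modest and rests on one pair. Nothing measured here bears on the reason for this step.

The compounds shown leave open whether the rise follows from losing the hydroxy hydrogen or from adding the methyl, a question that an amine or a longer ethoxy chain at this place could help to settle. They also leave open whether the same step would appear with 3-(trifluoromethyl)phenyl in place of 4-fluorophenyl.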